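This account rests on a few compounds, and the source may have more. Where it says the series, first, only, none or still open, it means among the compounds named here.

Measured compounds:
- compound 1 `CCON=C1CCC(CN2CCN(c3nc(=O)c4cc(C(F)(F)F)cc([N+](=O)[O-])c4s3)C[C@@H]2C)CC1`: > 64 ug/mL
- compound 2 `CON=C1CCC(CN2CCN(c3nc(=O)c4cc(C(F)(F)F)cc([N+](=O)[O-])c4s3)C[C@H]2C)CC1`: > 64 ug/mL

The account concerns two measured compounds and one that is not yet measured. In an ADME assay on Vero cells (Chlorocebus sabaeus) for cytotoxicity (on this read-out lower numbers stand for higher toxicity in this test and higher numbers for lower toxicity in this test), compound 1 gives > 64 ug/mL, which is a limit of the assay rather than a number. In this assay compound 2 likewise gives > 64 ug/mL, again a limit and not a number. Compound 2 therefore stands at the same limit as compound 1, and neither value can be placed above or below the other; this is summed up by the limit of > 64 ug/mL in this assay, at which 2 of the 2 values shown sit.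

Compound 3 `CCON=C1CCC(CN2CCN(c3nc(=O)c4cc(C(F)(F)F)cc([N+](=O)[O-])c4s3)C[C@H]2C)CC1` is the compound still to be measured. It differs from compound 2 by methyl in place of hydrogen on a saturated chain carbon bound to an oxygen on an unsaturated carbon. Among the measured compounds shown here, no measured pair here shows what such a change does in this assay; the only guidance is that compound 1, which carries the ethoxy group with the other configuration at the methyl-bearing carbon, and compound 2 both sit at the limit. The expectation is therefore for no step beyond the scatter, with compound 3 estimated at 80 ug/mL (32 ug/mL to 160 ug/mL), an expected step that the limit leaves unreadable from compound 2 to compound 3, most probably reported again only as a limit.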

Compound 3, half-maximal cytotoxic concentration: > 64 ug/mL
Compound 3: only a limit was reported; the forecaster's own chance of this, stated with the estimate: 85%; the middle value is on the limit's open side.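

Compound 3 gives > 64 ug/mL in this assay and this is a limit of the assay, not a number. Among the compounds shown here, no step from compound 1 or compound 2 to compound 3 can be read. The compounds shown leave open whether methoxy to ethoxy, or the stereocentre at a saturated ring carbon drawn S or R, changes the read-out in this assay at all.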